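The source may hold more compounds than are shown below. What is called first, only, known or untested is meant among the compounds shown, and "the series" means these compounds.

Two compounds have been measured in an assay on isolated protein for binding affinity to somatostatin receptor type 3 (Homo sapiens); a lower number here means tighter binding, a higher number weaker binding:

Compound 1 `COC(=O)c1cc(CC(C)CN2C[C@H]3CCCC[C@H]3[C@@H](C(=O)N3CCN(c4ccc([N+](=O)[O-])cc4)CC3)C2)cc(C(=O)OC)c1` gives 107 nM.
Compound 2 `Cc1nc2cc(C[C@H](C)CN3C[C@@H]4CCCC[C@@H]4[C@H](C(=O)N4CCN(c5ccc(F)c(F)c5)CC4)C3)ccc2o1` gives 3.39 nM.

Compound 2 has the lowest number of the two in this assay, and the gap to compound 1 is far beyond the usual scatter, so compound 2 binds more tightly. The two differ at several places at once, so no single change can be read from this pair.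

Compound 3 `CCOc1ccc(C[C@H](C)CN2C[C@@H]3CCCC[C@@H]3[C@H](C(=O)N3CCN(c4ccc(F)c(F)c4)CC3)C2)cn1` is a close relative of compound 2. Among the compounds with values here, the only change is 6-ethoxypyridin-3-yl in place of 2-methyl-1,3-benzoxazol-5-yl on a saturated chain carbon, three bonds along the chain from an amine nitrogen in a ring. The group that leaves and the group that enters are of similar size and each carries two hydrogen-bond acceptors, so the change is a modest one on paper. Within the data shown here, no measured pair shows the effect of this swap, so the direction cannot be taken from the data. A small step, within or only just beyond the scatter, is expected in this assay, with a slight lean toward a weaker number.

On that basis, compound 3 is expected to give about 6 nM in this assay, with a range from 1.5 nM to 25 nM, which means an expected step of a 1.8-fold higher number from compound 2 to compound 3 (0.25 log units; within the scatter).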

Compound 3, dissociation constant: 14.1 nM
Estimate against measurement, compound 3: 2.4-fold (0.37 log units) below; measured number inside the range.
By their numbers in this assay, from the lowest: compound 2; then compound 3; then compound 1.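

Within the data shown here, this is the first comparison that differs in one place only, so the group on a saturated chain carbon, three bonds along the chain from an amine nitrogen in a ring, can now be read on its own in this assay and not mixed with other changes. Putting 6-ethoxypyridin-3-yl in place of 2-methyl-1,3-benzoxazol-5-yl gives a 4.2-fold higher number from compound 2 to compound 3 (0.62 log units; beyond the scatter) and shows that binding responds to this position, even though both groups carry the same counts of hydrogen-bond donors and acceptors and neither has a net charge. Nothing available explains why the number moves this way.

The swap changes two things together, replacing a two-ring group with a single ring and adding an ethoxy group, so the compounds shown leave open which of these matters. From the compounds shown here alone, a 6-methoxypyridin-3-yl group or a plain pyridin-3-yl group on the same carbon would help to separate the two, and it also remains open whether the step would hold with a different group at the far end of the molecule.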